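The source may report more compounds than this note shows. Statements on the series, on what has been measured and on what is new or still open speak of the compounds shown alone.

Working notes on the thiosemicarbazone-type series, all sharing the core of compound 1. In a functional assay on NCI-H460 cells (Homo sapiens) for cytotoxicity, read by sulforhodamine B assay (a lower number here means a stronger inhibitor of growth, a higher number a weaker inhibitor of growth), compound 1 (`CC1=CC[C@@H]([C@@](C)(O)CCCC(C)(C)NC(=S)N/N=C\c2ccc(O)cc2)CC1`) gives 20700 nM. Compound 2 (`CC1=CC[C@@H]([C@@](C)(O)CCCC(C)(C)NC(=S)N/N=C\c2ccc(N(C)C)cc2)CC1`) gives > 100000 nM, which is a limit of the assay and not a number. Compound 3 (`CC1=CC[C@@H]([C@@](C)(O)CCCC(C)(C)NC(=S)N/N=C\c2cccc([N+](=O)[O-])c2)CC1`) gives 68600 nM, the higher of the two actual numbers, and the measured gap is a 3.3-fold higher number from compound 1 to compound 3 (0.52 log units; beyond the scatter).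

Next is compound 4 (`CC1=CC[C@@H]([C@@](C)(O)CCCC(C)(C)NC(=S)N/N=C\c2cccc(Cl)c2)CC1`), with chloro in place of nitro on an aromatic carbon. Going by the values given here, no measured step makes this exchange, and no measured compound carries chloro. Two steps reach compound 3, and each swaps the whole aryl group: a 3.3-fold higher number from compound 1 to compound 3 (0.52 log units; beyond the scatter), and an at least 1.4-fold lower number from compound 2 to compound 3 (0.16 log units; that floor lies within the scatter), whose floor lies within the scatter. They show that the aryl group can move the number modestly, but they give neither a size nor a direction for this exchange. Compound 1 at 20700 nM offers only a weak pull towards a lower number. The expected change in this assay is therefore small: a 1.5-fold lower number from compound 3 to compound 4 (0.18 log units; within the scatter), an estimate not clearly beyond the scatter. For compound 4 the estimated value is 45000 nM, with an expected range of 18000 nM to 100000 nM.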

Compound 4, concentration for total growth inhibition: > 100000 nM
Compound 4: only a limit was reported (the forecaster's own chance of this, stated with the estimate: 15%); middle value at least 2.2-fold (0.34 log units) away from the limit.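

In this assay compound 4 gives > 100000 nM, which is a limit of the assay and not a number. Going by these compounds alone, this is the first exchange that keeps the place fixed, on an aromatic carbon meta to a large group, and changes only the group there, and it reads an at least 1.4-fold higher number from compound 3 to compound 4 (0.16 log units; that floor lies within the scatter); chloro therefore shows no gain over nitro at this position, although the floor of the step does not by itself settle a loss. Taking the whole aryl exchange, 3-chlorophenyl in place of 4-hydroxyphenyl reads an at least 4.8-fold higher number from compound 1 to compound 4 (0.68 log units; beyond the scatter), the step between compound 2 and compound 4 cannot be read, and only compound 1 and compound 3 remain as actual numbers, with the rest of the set at the ceiling: the limit of > 100000 nM in this assay, at which 2 of the 4 values shown sit.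

As far as these compounds go, how far compound 4 lies past that limit stays unknown, so the size of the nitro to chloro step remains open. Also open, from the compounds shown here alone, is whether a hydroxy, an amine or a carboxylic acid on this same aromatic carbon would keep a readable number, which would separate the effect of the group from that of its place.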